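A few compounds are considered here, and "the series" means these few. Any claim that something is new, unique, unknown or untested is made for them only; others in the source may bear on it.

Measured so far:
Compound 1 `CNc1ccc(/C=C/c2c(F)cccc2F)cn1`: 30.1 nM
Compound 2 `CCNc1ccc(/C=C/c2c(F)cccc2F)cn1`: 31.3 nM
Compound 3 `CNc1ncc(/C=C/c2c(F)cccc2F)cn1`: > 200 nM

In a functional assay on LS174T cells (Homo sapiens) for antiproliferative activity (a lower number here means a stronger inhibitor, a higher number a weaker inhibitor), compound 1 gives 30.1 nM and compound 2 gives 31.3 nM. The two differ by methyl in place of hydrogen on a saturated chain carbon bound to a nitrogen on an aromatic ring, and that change produced a 1.0-fold higher number from compound 1 to compound 2 (0.02 log units; within the scatter). Compound 3 gives only > 200 nM, which is a limit of this assay and not a number; it sits at the limit of > 200 nM in this assay, at which 1 of the 3 values shown sits. The difference between the core of compound 1 and the core of compound 3 is not broken down here.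

Compound 4 `CCNc1ncc(/C=C/c2c(F)cccc2F)cn1` has not yet been measured in this assay. It differs from compound 3 by methyl in place of hydrogen on a saturated chain carbon bound to a nitrogen on an aromatic ring, the same change as between compounds 1 and 2, made on the core of compound 3. Since that change left compound 1 and compound 2 within the scatter of each other, the step is expected to be equally small here. Compound 4 is therefore estimated at about 300 nM, most likely between 150 nM and 1000 nM. The expected step, a step that the limit leaves unreadable from compound 3 to compound 4, rests on compound 3 being itself only a limit, so compound 4 is expected most probably to return a limit as well.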

Compound 4, half-maximal inhibitory concentration: > 200 nM
Compound 4 ended at the assay's limit; the forecaster's own chance of this, stated with the estimate: 75%; the middle value is on the limit's open side.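

In this assay compound 4 gives > 200 nM, which is a limit of the assay and not a number. Compound 3 gives > 200 nM, also a limit, so the step between compound 3 and compound 4 cannot be read. The compounds shown leave open whether methyl in place of hydrogen changes anything on the core of compound 3.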